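The source may report more compounds than this note shows. Statements on the series, on what has been measured and on what is new or still open speak of the compounds shown alone.

In an assay on isolated protein for inhibition of Rho-associated protein kinase 2 (Homo sapiens), read by scintillation counting, radiometric assay and 33P incorporation, with a stated time of 40 min, in the presence of a further agent that is not named here (on this read-out higher numbers stand for weaker inhibition and lower numbers for stronger inhibition), compound 3 `O=C(COc1ccc2c(=O)ccoc2c1)Nc1cccc(NC(=O)c2ccc(F)cc2)c1` gives 54 nM, the lowest of the three numbers. Compound 1 `Cc1coc2cc(OCC(=O)Nc3cccc(NC(=O)c4ccc(N(C)C)cc4)c3)ccc2c1=O` gives 2150 nM and compound 2 `Cc1c(OCC(=O)Nc2cccc(NC(=O)c3ccc(N(C)C)cc3)c2)ccc2c(=O)ccoc12` gives 4160 nM in this assay; both gaps to compound 3 lie beyond the scatter, so compound 3 is the strongest inhibitor of the three measured. Compound 4 `Cc1cc(C(=O)Nc2cccc(NC(=O)COc3ccc4c(=O)ccoc4c3)c2)ccc1C(F)(F)F` differs from compound 3 in one place: a group of 11 heavy atoms (8 carbon, 3 fluorine; one six-membered aromatic ring of carbon only) in place of a group of 7 heavy atoms (6 carbon, 1 fluorine; one six-membered aromatic ring of carbon only), on a carbonyl carbon. For the measured compounds named here, no step between measured compounds matches this change, as compounds 1 and 2 differ from compound 3 at more than one point. The step expected in this assay is a 2.2-fold higher number from compound 3 to compound 4 (0.35 log units; beyond the scatter), modest and toward weaker inhibition, or none beyond the scatter. Compound 4 is estimated at 120 nM, with a range of 30 nM to 500 nM.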

Compound 4, half-maximal inhibitory concentration: 43 nM
Compound 4: middle estimate off by 2.8-fold (0.45 log units), on the high side, and the stated range covers the measured number.
By their numbers in this assay, from the lowest: compounds 4 and 3 (each within the scatter of the next); then compounds 1 and 2 (each within the scatter of the next).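

In this assay, the position on the carbonyl carbon accepts the group of 11 heavy atoms in place of 4-fluorophenyl, with a 1.3-fold lower number from compound 3 to compound 4 (0.10 log units; within the scatter). This single one-place comparison therefore does not separate the two groups, and a larger aromatic group here still gives a number within the scatter of compound 3. No measurement at hand bears on why the two groups read alike.

Still open, as far as these compounds go, is whether a group without an aromatic ring, such as a longer alkyl chain, or a phenyl ring carrying a carboxylic acid, would hold this level at this position. The gaps to compounds 1 and 2 also remain unassigned, since those compounds differ from compound 3 at more than one point.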